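The source may report more compounds than this note shows. Statements on the series, on what has been measured and on what is new or still open speak of the compounds shown alone.

Compound 1 `Cc1nsc2c1nc(SCc1ccccc1)n2[C@H]1C[C@H](O)[C@@H](CO)O1`: in a functional assay on HFF cells (Homo sapiens) for inhibition (a higher number here means a weaker inhibitor, a lower number a stronger inhibitor), compound 1 gives > 100000 nM, a limit of the assay.
Compound 2 `Cc1nsc2c1ncn2[C@@H]1O[C@H](CO)[C@@H](O)[C@@H]1O`: compound 2 gives > 100000 nM, a limit.
Compound 3 `CSc1nc2c(C)nsc2n1[C@@H]1O[C@H](CO)[C@@H](O)[C@@H]1O`: compound 3 gives > 100000 nM, a limit.

Compound 3 therefore stands at the limit of this assay, as do the other two values, see (the limit of > 100000 nM in this assay, at which 3 of the 3 values shown sit). For the measured compounds named here, the only single-point step measured, a step that the two limits leave unreadable from compound 2 to compound 3, is unreadable between two limits, so its size is unknown. Compound 4 `Cc1nsc2c1nc(SCc1ccccc1)n2[C@@H]1O[C@H](CO)[C@@H](O)[C@@H]1O` differs from compound 3 by phenyl in place of hydrogen on a saturated chain carbon bound to a sulfur. Going by the values given here, no measured step reads on this change. Compound 1 carries benzylsulfanyl on a different sugar and gives only a limit. The expectation is that compound 4 remains at the limit, with a number no higher from compound 3 to compound 4 (the limit leaves the size open) as the expected step. Compound 4 is estimated at 100000 nM, range 30000 nM to 300000 nM.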

Compound 4, half-maximal inhibitory concentration: > 100000 nM
Compound 4: a limit, no number (the forecaster's own chance of this, stated with the estimate: 85%); the middle value sits exactly at the limit.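

For the compounds shown here, compound 4 also sits at a limit, so no step from compound 1, compound 2 or compound 3 to compound 4 can be read: the limit of > 100000 nM in this assay, at which 4 of the 4 values shown sit. The compounds shown leave open how strongly, if at all, any of them inhibits in this assay.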